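Replacing the isopropyl of compound 2 with a substituted oxolane

A few compounds are considered here, and "the series" means these few. Any claim that something is new, unique, unknown or untested is made for them only; others in the source may bear on it.

The study includes three measured compounds. Compound 1 `C=Cc1cn2ncc(-c3ccnc(OC)c3)c2nc1NC` gives 190 nM in an assay on isolated protein for inhibition of activin receptor type-2A (Homo sapiens), read by 33P incorporation, with a stated time of 20 min, in the presence of a further agent that is not named here; on this read-out lower numbers stand for stronger inhibition and higher numbers for weaker inhibition. Compound 2 `COc1cc(-c2cnn3cc(OC)c(C(C)C)nc23)ccn1` gives 3800 nM in this assay, and compound 3 `COc1cn2ncc(-c3ccnc(OC(C)C)c3)c2nc1-c1cnn(C)c1` gives 2300 nM. Compound 2 stands at the highest number of the three; its gap to compound 3 lies within the scatter of repeated measurements, while compound 1 sits well beyond it, at a much lower number.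

Compound 4 `COc1cc(-c2cnn3cc(OC)c([C@H]4COC(C)(C)C4)nc23)ccn1` has not yet been measured. It differs from compound 2 in one place: a group of 7 heavy atoms (6 carbon, 1 oxygen; one five-membered non-aromatic ring with 1 hetero atom) in place of a group of 3 heavy atoms (3 carbon; no ring), on an aromatic carbon. Among the measured compounds shown here, no step between two measured compounds isolates this kind of change, so the size and direction of the step from compound 2 to compound 4 cannot be read off any measured pair. The change adds a ring and a hydrogen-bond acceptor where none was, and the expected step of a 1.9-fold lower number from compound 2 to compound 4 (0.28 log units; within the scatter) is taken to be small and toward a lower number, not clearly beyond the scatter. Compound 4 is accordingly estimated at 2000 nM, with a range from 500 nM to 8000 nM.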

Compound 4, half-maximal inhibitory concentration: 4100 nM
Compound 4: the middle estimate sits 2.1-fold (0.31 log units) below what was measured; low and high end bracket the measured number.
By their numbers in this assay, from the lowest: compound 1; then compounds 3, 2 and 4 (each within the scatter of the next).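

In this assay, placing the substituted oxolane on this aromatic carbon, next to the ring nitrogen, in place of isopropyl gives a 1.1-fold higher number from compound 2 to compound 4 (0.03 log units; within the scatter). Among the compounds shown here, this is the first reading of a change at this position, and it shows that a larger group bearing a ring, a hydrogen-bond acceptor and a defined stereocentre can stand here with no difference beyond the scatter. Nothing measured accounts for this outcome.

The compounds shown leave open whether the opposite configuration at the stereocentre, or the same ring without its two methyl groups, would give a different number. They also leave open whether a carboxylic acid or a longer chain such as butyl at this position would move the number beyond the scatter.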